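Thiazoline to oxazoline swap on a pyrazole sulfone

A few compounds are considered here, and "the series" means these few. Any claim that something is new, unique, unknown or untested is made for them only; others in the source may bear on it.

Measured compounds:
compound 1 `O=S(=O)(CC1=NCCO1)c1n[nH]cc1-c1ccc(Cl)cc1` gives "not active" (no number reported)
compound 2 `O=S(=O)(CC1=NCCO1)c1n[nH]cc1-c1ccccc1` gives 50.6%
compound 3 `Cc1ccc(-c2c[nH]nc2S(=O)(=O)CC2=NCCS2)cc1` gives "not active" (no number reported)

In a functional assay, read by Griess assay, with a stated time of 150 min, tested at 50 ug/mL (on this read-out higher numbers stand for a stronger effect at the one concentration tested and lower numbers for a weaker effect), compound 3 stands without a single number; it is one of two entries in this set for which no number was reported, the other being compound 1, which in this assay also gives "not active" (no number reported). Only compound 2 carries a measured value, and in this assay compound 2 gives 50.6%.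

Compound 4 `Cc1ccc(-c2c[nH]nc2S(=O)(=O)CC2=NCCO2)cc1` is not yet measured. It differs from compound 3 in one place: a group of 5 heavy atoms (3 carbon, 1 nitrogen, 1 oxygen; one five-membered non-aromatic ring with 2 hetero atoms) in place of a group of 5 heavy atoms (3 carbon, 1 nitrogen, 1 sulfur; one five-membered non-aromatic ring with 2 hetero atoms), on a saturated chain carbon bound to a sulfonyl sulfur. For the measured compounds named here, the same five-membered ring that enters here is the one already carried by compound 2 and compound 1, and those two compounds show that with this ring the outcome depends on the aryl group: compound 2 gives a clear number while compound 1 gives none.

Going by the values given here, since no measured step is available between compound 3 and compound 4, the size of the change is open. A shift in the direction of a stronger effect in this assay is considered possible, but a result that again stays without a number cannot be excluded. For compound 4 the estimated value in this assay is 25%, expected between 0% and 55%.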

Compound 4, a percentage reported as activity, at one concentration (the size of the read-out at that concentration, not a potency): 59.4%
Compound 4: middle estimate off by 34.4 percentage points, on the low side; the measured number lies above the stated range.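

In this assay compound 3, with the sulfur-bearing ring, gives ("not active" (no number reported)) while compound 4, with the oxygen-bearing ring and the same methyl-carrying aryl group, gives (59.4%), so on a saturated chain carbon bound to a sulfonyl sulfur this one exchange separates an entry without a number from a clear reading. The methyl step in this assay is a number 8.8 percentage points higher from compound 2 to compound 4 (within the scatter) and therefore does not distinguish the two oxygen-ring compounds, although compound 1, with chlorine on the aryl group, still gives ("not active" (no number reported)), so the oxygen-bearing ring does not yield a number with every aryl group shown. Nothing among the data given explains why the sulfur-to-oxygen exchange or the chlorine has this outcome.

Compound 3 is the only sulfur-ring compound shown, so it remains open whether that ring gives no number with the unsubstituted phenyl group or with other aryl groups as well. As far as these compounds go, how a methoxy group or a carboxylic acid on the aryl group would read, or an amine nitrogen in place of the ring oxygen, also remains open.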